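Amine and ether variation on the urea-bearing ring

This account rests on a few compounds, and the source may have more. Where it says the series, first, only, none or still open, it means among the compounds named here.

Measured so far:
compound 1 `Cc1ccc(NC(=O)Nc2cc(-c3ccccc3C(=O)O)ccc2Oc2ccccc2C(C)(C)C)cc1`, in an assay on HeLa cells for inhibition of Indoleamine 2,3-dioxygenase 1 (Homo sapiens), with stated times of 1 h and 18 h; a lower number here means a stronger inhibitor, a higher number a weaker inhibitor: 70 nM
compound 2 `Cc1ccc(NC(=O)Nc2cc(-c3ccc(C(=O)O)cc3)ccc2Oc2ccccc2C(C)(C)C)cc1`, in this assay: > 1000 nM
compound 3 `Cc1ccc(NC(=O)Nc2cc(-c3ccccc3C(=O)O)ccc2NC2CCCCC2)cc1`, in this assay: 504 nM

The value of compound 2 is a limit of the assay and not a number (the limit of > 1000 nM in this assay, at which 1 of the 3 values shown sits). Of the two numbers shown, compound 3 stands highest; its nearest neighbour is compound 1, with a 7.2-fold higher number from compound 1 to compound 3 (0.86 log units; beyond the scatter). The other measured step, an at least 14-fold higher number from compound 1 to compound 2 (1.15 log units; beyond the scatter), concerns the carboxyphenyl group and does not touch the position varied here.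

Compound 4 `CCCCN(CCCC)c1ccc(-c2ccccc2C(=O)O)cc1NC(=O)Nc1ccc(C)cc1` differs from compound 3 in one place: dibutylamino in place of cyclohexylamino on an aromatic carbon. Going by the values given here, only a 7.2-fold higher number from compound 1 to compound 3 (0.86 log units; beyond the scatter) bears on this position, and it compares an ether with an amine, not one amine with another; no measured step replaces cyclohexylamino by an open-chain dialkylamino group. With no such comparison, the step of a 1.1-fold lower number from compound 3 to compound 4 (0.05 log units; within the scatter) is expected to stay within the scatter, with a wide range. Compound 4 is therefore estimated at 450 nM, between 120 nM and 1700 nM.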

Compound 4, half-maximal inhibitory concentration: 45 nM
Beside the measured number, compound 4's estimate is 10-fold (1.00 log units) above it, and the stated range ends above it.
By their numbers in this assay, from the lowest: compounds 4 and 1 (each within the scatter of the next); then compound 3. At a limit, above all of these: compound 2.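

In this assay the choice of amine at this position matters, not only the choice between ether and amine (an 11-fold lower number from compound 3 to compound 4 (1.05 log units; beyond the scatter)), though this one step exchanges cyclohexylamino, with its ring and hydrogen-bond donor, for dibutylamino, which has neither. Dibutylamino and 2-(tert-butyl)phenoxy cannot be told apart on these data (a 1.6-fold lower number from compound 1 to compound 4 (0.19 log units; within the scatter)), so an aryl ether is not required for a number in this range among the compounds shown. No measured property shown here bears on either step.

Whether the ring, the amine hydrogen or the chain length accounts for the difference stays open; dipropylamino, piperidin-1-yl and methyl(cyclohexyl)amino groups would separate these features. Also open, as far as these compounds go, is whether 4-carboxyphenyl in place of 2-carboxyphenyl has a comparable effect in the dibutylamino series.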